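The source may report more compounds than this note shows. Statements on the series, on what has been measured and on what is new or still open speak of the compounds shown alone.

Measured in a functional assay on PC-3 cells (Homo sapiens) for cytotoxicity, read by sulforhodamine B assay, with a stated time of 72 h; on this read-out lower numbers stand for stronger inhibition and higher numbers for weaker inhibition:
- compound 1, `Nc1sc(-c2ccc(F)cc2)c(-c2ccc(Cl)cc2)c1C(=O)N1CCCC1`: 20400 nM
- compound 2, `Nc1sc(-c2ccc(Br)cc2)c(-c2ccc(Cl)cc2)c1C(=O)NC1CCCCC1`: 28400 nM

Compound 2 and compound 1 share the same core, with two para-substituted aryl rings on the thiophene and an amide on the remaining position; they differ in the halogen on one aryl ring and in the amide substituent. Among the compounds with values here, their two values in this assay lie within the scatter of each other, so nothing separates them in potency, and no step between them is given.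

Compound 3, `Nc1sc(-c2ccc(Br)cc2)c(-c2ccc(Cl)cc2)c1C(=O)N1CCCC1`, is not yet measured. Relative to compound 2 the change is pyrrolidin-1-yl in place of cyclohexylamino on a carbonyl carbon. This is the amide substituent that compound 1 already carries, on the brominated aryl pairing of compound 2.

Within the data shown here, since both measured compounds give similar weak values and no single-point step is available, the change from compound 2 to compound 3 is expected to produce no step beyond the scatter in this assay, a 1.3-fold lower number from compound 2 to compound 3 (0.11 log units; within the scatter). Compound 3 is therefore expected at about 22000 nM, within a range of 7000 nM to 65000 nM.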

Compound 3, half-maximal inhibitory concentration: 37500 nM
For compound 3 the middle estimate is 1.7-fold (0.23 log units) below the measured one; measured number inside the range.
By their numbers in this assay, from the lowest: compounds 1, 2 and 3 (each within the scatter of the next).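

In this assay, within the data shown here, pyrrolidin-1-yl in place of cyclohexylamino on a carbonyl carbon gives a 1.3-fold higher number from compound 2 to compound 3 (0.12 log units; within the scatter), the first reading of this amide position with only one place changed, and the two groups are not separated even though cyclohexylamino has 1 hydrogen-bond donor and pyrrolidin-1-yl has 0. Bromo in place of fluoro on an aromatic carbon gives a 1.8-fold higher number from compound 1 to compound 3 (0.26 log units; within the scatter), so this halogen exchange, which could not be read on its own from compound 1 and compound 2, is not separated in this assay either. No measurement of any property is available to explain these two results.

Both steps stay within the scatter, so the compounds shown establish no effect of either change, and they cannot tell whether a group of a different kind on the carbonyl carbon, such as morpholin-4-yl, piperazin-1-yl or a longer chain like hexylamino, would move the number in this assay. Also open, from the compounds shown here alone, is whether replacing the halogen with methoxy or a nitrile on the shared core would give a step beyond the scatter.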